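A few compounds are considered here, and "the series" means these few. Any claim that something is new, unique, unknown or untested is made for them only; others in the source may bear on it.

Measured so far: compound 1 `CCn1c([C@@H](C)NS(=O)(=O)c2ccc(Cl)cc2)nc2ccc(CN(C)C)cc21`, compound 2 `CCn1c([C@@H](C)NS(=O)(=O)c2ccc(Cl)cc2)nc2ccc(S(C)(=O)=O)cc21`, compound 3 `CCn1c([C@@H](C)NS(=O)(=O)C2CC2)nc2ccc(C(F)(F)F)cc21`.

In an ADME assay (liver) for metabolic stability, with Liver microsome (Homo sapiens) as the target, read by LC-MS, using microsomes and NADPH, with a stated time of 5 min, at 37 degrees C (on this read-out lower numbers stand for slow clearance and higher numbers for fast clearance), compound 1 gives 30 mL.min-1.g-1. Compound 2 gives only a limit of the assay, < 5 mL.min-1.g-1. The step between them is an at least 6.0-fold lower number from compound 1 to compound 2 (0.77 log units; beyond the scatter). Compound 3 also gives only a limit of the assay, < 3 mL.min-1.g-1, so its exact position is not known; it sits at the limit of < 3 mL.min-1.g-1 in this assay, at which 1 of the 3 values shown sits.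

Compound 4 `CCCn1cc(S(=O)(=O)N[C@H](C)c2nc3ccc(C(F)(F)F)cc3n2CC)c(C)n1` differs from compound 3 in one place: a group of 9 heavy atoms (7 carbon, 2 nitrogen; one five-membered aromatic ring with 2 hetero atoms) in place of a group of 3 heavy atoms (3 carbon; one three-membered non-aromatic ring of carbon only), on a sulfonyl sulfur. Going by the values given here, the only measured step, from compound 1 to compound 2, concerns a group on an aromatic carbon, not the sulfonyl sulfur, so no measured step bears on this change directly. The step from compound 3 to compound 4 in this assay is therefore expected to be an at least 2.6-fold higher number from compound 3 to compound 4 (0.42 log units; beyond the scatter), with wide uncertainty. Compound 4 is estimated to give 8 mL.min-1.g-1, between 2 mL.min-1.g-1 and 35 mL.min-1.g-1.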

Compound 4, intrinsic clearance in microsomes: > 100 mL.min-1.g-1
Compound 4: a limit, no number; the forecaster's own chance of this, stated with the estimate: 35%; middle value at least 12-fold (1.09 log units) away from the limit.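

In this assay, the group on the sulfonyl sulfur proves to matter greatly: the nine-heavy-atom aromatic group in place of cyclopropyl gives an at least 33-fold higher number from compound 3 to compound 4 (1.52 log units; beyond the scatter). Going by these compounds alone, the earlier readable step concerned only a group on an aromatic carbon, so this is the first measured change at the sulfonyl sulfur. Compound 4 sits at a limit of the assay, not at a number: the limit of > 100 mL.min-1.g-1 in this assay, at which 1 of the 4 values shown sits.

Going by these compounds, whether a small group such as methyl on the sulfonyl sulfur would stay close to compound 3 remains open. Also open, on these data alone, is how far the true clearance of compound 4 lies past its limit.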